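This account rests on a few compounds, and the source may have more. Where it says the series, first, only, none or still open, it means among the compounds named here.

Three members of this series have been measured so far. Compound 1 `COc1ccc(/C=C2\CCC/C(=C\c3ccccc3Cl)C2=O)cc1OC` gives 6800 nM in a functional assay on HT-1080 cells (Homo sapiens) for cytotoxicity, read by MTT assay, with a stated time of 72 h; a higher number here means a weaker inhibitor, a lower number a stronger inhibitor. Compound 2 `COc1ccccc1/C=C1\CCC/C(=C\c2ccc(OC)c(OC)c2)C1=O` gives 8100 nM in this assay, and compound 3 `COc1ccc(/C=C2\CCC/C(=C\c3ccc(O)c(Cl)c3)C2=O)cc1OC` gives 7600 nM. All three sit close together: a 1.2-fold higher number from compound 1 to compound 2 (0.08 log units; within the scatter), a 1.1-fold higher number from compound 1 to compound 3 (0.05 log units; within the scatter), a 1.1-fold lower number from compound 2 to compound 3 (0.03 log units; within the scatter).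

Going by the values given here, the one change for which a direct comparison exists is methoxy in place of chloro on an aromatic carbon. Compound 4 `COc1cc(/C=C2\CCC/C(=C\c3ccc(OC)c(OC)c3)C2=O)ccc1O` carries the same kind of change against compound 3, namely (methoxy in place of chloro on an aromatic carbon). The cores differ as 3-chloro-4-hydroxyphenyl in place of 2-chlorophenyl on a double-bonded chain carbon bound to a double-bonded ring carbon. The surroundings of the change are not the same: in compound 1 the chloro sits ortho to a large group, whereas in compound 3 it sits ortho to a hydroxy group (1 heavy atom) and meta to a large group.

Because a 1.2-fold higher number from compound 1 to compound 2 (0.08 log units; within the scatter) is within the scatter, compound 4 is expected to stay near compound 3, with an expected step of a 1.1-fold higher number from compound 3 to compound 4 (0.05 log units; within the scatter) in this assay. The estimate for compound 4 in this assay is 8500 nM, expected to fall between 4500 nM and 16000 nM.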

Compound 4, half-maximal inhibitory concentration: 4600 nM
Estimate against measurement, compound 4: 1.8-fold (0.27 log units) above, within the range that was stated.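

Methoxy in place of chloro on an aromatic carbon can now be compared on two cores in this assay, and the two steps do not differ: the same change on two cores in this assay, a 1.2-fold higher number (0.08 log units; within the scatter) from compound 1 to compound 2 and a 1.7-fold lower number (0.22 log units; within the scatter) from compound 3 to compound 4, 2.0-fold (0.29 log units) apart, within the scatter of two such steps. The new step reads a 1.7-fold lower number from compound 3 to compound 4 (0.22 log units; within the scatter), and the other two steps, a 1.8-fold lower number from compound 2 to compound 4 (0.25 log units; within the scatter) and a 1.5-fold lower number from compound 1 to compound 4 (0.17 log units; within the scatter), also stay within the scatter, so no order can be drawn among the four compounds. The change therefore carries between these two cores without a shift that can be told from the scatter, but with steps this small the comparison does not show that a larger effect would carry, and it says nothing about any other core.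

Still open, from the compounds shown here alone, is whether an amine or a carboxylic acid in place of the chloro or methoxy of the 4-hydroxyphenyl ring would give a step beyond the scatter. Also open, going by these compounds, is whether a longer chain on the oxygen of the methoxy would do so.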